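Methoxy added to the shared core: compounds 1, 2 and 3

The compounds below may be only part of what the source reports. "The series", "measured", "known", "first", "only" and "open" are said of these compounds alone.

Measured compounds:
compound 1 `COc1ccc(C(=O)/C=C/c2cc(-c3cc(OC)c(OC)c(OC)c3)n[nH]2)cc1OC` — 96%
compound 2 `COc1ccc(C(=O)/C=C/c2cc(-c3cc(OC)c(OC)c(OC)c3)n[nH]2)cc1` — 99%

In a functional assay on PC-3 cells (Homo sapiens) for cytotoxicity, read by sulforhodamine B assay, with a stated time of 48 h, tested at 0.01 uM (a lower number here means a stronger effect, a higher number a weaker effect of the compound at the concentration tested), compound 1 stands at 96%, and compound 2 stands at 99%, the two within the scatter of each other. Among the compounds with values here, the single measured step, a number 3 percentage points higher from compound 1 to compound 2 (within the scatter), is hydrogen in place of methoxy on an aromatic carbon.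

Compound 3 `COc1cc(C(=O)/C=C/c2cc(-c3cc(OC)c(OC)c(OC)c3)n[nH]2)cc(OC)c1OC` differs from compound 1 by methoxy in place of hydrogen on an aromatic carbon. The measured step bears on this change as its reverse and stayed within the scatter, so nothing beyond the scatter is expected here in this assay. The expected step is a number 1 percentage points higher from compound 1 to compound 3 (within the scatter). Compound 3 is therefore estimated at 97%, within 88% to 105%.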

Compound 3, a percentage reported as activity, at one concentration (the size of the read-out at that concentration, not a potency): 95%
Compound 3: middle estimate off by 2 percentage points, on the high side, and the stated range covers the measured number.
By their numbers in this assay, from the lowest: compounds 3, 1 and 2 (each within the scatter of the next).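

In this assay, methoxy in place of hydrogen on the aromatic carbon ortho to a methoxy group and meta to a large group gives a number 1 percentage points lower from compound 1 to compound 3 (within the scatter) and so adds a second methoxy change on this ring that does not separate from compound 1. Adding the group here thus leaves the read-out as undisturbed as the earlier removal of a methoxy did. No available data bear on the reason for this result. Open, going by these compounds, is whether an amine or a carboxylic acid on this carbon would shift the read-out, and whether these compounds separate at other concentrations.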